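A Side-Chain Swap at the Limit of a Cytotoxicity Test

The source may hold more compounds than are shown below. What is called first, only, known or untested is meant among the compounds shown, and "the series" means these compounds.

In an ADME assay on MT4 cells (Homo sapiens) for cytotoxicity, read by MTT assay, with a stated time of 5 days (on this read-out higher numbers stand for lower toxicity in this test and lower numbers for higher toxicity in this test), compound 1 (`CCCC(CCC)Nc1cc(Oc2c(OC)cc3cc(C#N)ccc3c2OC)nc(Nc2ccc(C#N)cc2)n1`) gives > 125000 nM, which is a limit and not a number. Compound 2 (`COc1cc2cc(C#N)ccc2c(OC)c1Oc1cc(NCCC2=CCCCC2)nc(Nc2ccc(C#N)cc2)n1`) gives > 125000 nM, which is also a limit and not a number. Compound 2 therefore stands at the limit of > 125000 nM in this assay, at which 2 of the 2 values shown sit. Among the measured compounds shown here, the only measured step is a step that the two limits leave unreadable from compound 1 to compound 2, so it offers no size to carry forward. Compound 3 (`COc1cc2cc(C#N)ccc2c(OC)c1Oc1cc(NCC2CCOC2)nc(Nc2ccc(C#N)cc2)n1`) keeps the shared core and differs from compound 2 in one place: oxolan-3-yl in place of (cyclohex-1-en-1-yl)methyl on a saturated chain carbon bound to a nitrogen on an aromatic ring. In short, oxolan-3-yl replaces (cyclohex-1-en-1-yl)methyl on a saturated chain carbon bound to a nitrogen on an aromatic ring. With nothing readable from that earlier exchange, no change beyond the scatter is expected in this assay. The estimated step is a number no higher from compound 2 to compound 3 (the limit leaves the size open). The estimate for compound 3 is 125000 nM, with an expected range from 45000 nM to 250000 nM, and another limit is the likeliest report.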

Compound 3, half-maximal cytotoxic concentration: > 125000 nM
Compound 3: only a limit was reported (the forecaster's own chance of this, stated with the estimate: 80%); the middle value lies on the limit itself.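

In this assay the steps among compound 1, compound 2 and compound 3 cannot be read, since all three give only a limit and not a number: the limit of > 125000 nM in this assay, at which 3 of the 3 values shown sit. The compounds shown leave open whether these side chains differ in toxicity to these cells, and at what concentration any toxicity would appear.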